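The source may report more compounds than this note shows. Statements on the series, on what has been measured and on what is new or still open speak of the compounds shown alone.

The compounds measured in an assay on CHO cells for displacement of a labelled ligand from adenosine receptor A1 (Homo sapiens) (on this read-out lower numbers stand for stronger inhibition and higher numbers for weaker inhibition), so far:
Compound 1 `COc1ccc(CNc2ncc(C(=O)O)c3nc(-c4ccco4)nn23)cc1OC` gives 958 nM.
Compound 2 `CNc1ncc(C(=O)O)c2nc(-c3ccco3)nn12` gives > 100000 nM, which is a limit of the assay and not a number.
Compound 3 `CCCCC(CC)CNc1ncc(C(=O)O)c2nc(-c3ccco3)nn12` gives 1780 nM.

Compound 3 has the higher of the two numbers given; compound 1 sits a step away that lies within the scatter. Among the measured compounds shown here, one measured step bears on this position: an at least 56-fold lower number from compound 2 to compound 3 (1.74 log units; beyond the scatter), a large step that starts from a limit (the limit of > 100000 nM in this assay, at which 1 of the 3 values shown sits). Compound 4 `COc1ccc(CNc2ncc(C(=O)O)c3nc(-c4ccco4)nn23)cc1` differs from compound 3 by 4-methoxyphenyl in place of 1-ethylpentyl on a saturated chain carbon bound to a nitrogen on an aromatic ring. For the measured compounds named here, no measured step covers this exchange, but compound 1, carrying a related group at the same position, gives 958 nM. The step of a 1.6-fold lower number from compound 3 to compound 4 (0.21 log units; within the scatter) is therefore expected to be small. Compound 4 is estimated at 1100 nM, with a range from 350 nM to 3500 nM.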

Compound 4, inhibition constant: 5760 nM
For compound 4 the middle estimate is 5.2-fold (0.72 log units) below the measured one; measured number above the stated range.
By their numbers in this assay, from the lowest: compounds 1 and 3 (each within the scatter of the next); then compound 4. At a limit, above all of these: compound 2.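

In this assay, hydrogen in place of methoxy on an aromatic carbon gives a 6.0-fold higher number from compound 1 to compound 4 (0.78 log units; beyond the scatter), so the substitution of the aromatic ring, and not merely its presence, matters at this position. A 4-methoxybenzyl group also fails to match 2-ethylhexyl, with a 3.2-fold higher number from compound 3 to compound 4 (0.51 log units; beyond the scatter). The step of an at least 17-fold lower number from compound 2 to compound 4 (1.23 log units; beyond the scatter) starts from a limit of the assay and not a number, yet it shows that 4-methoxybenzyl still counts for much here. Open, on these data alone, is how an amine or a chlorine on the aromatic ring would compare with methoxy. Also open, as far as these compounds go, is whether an amide could stand in for the carboxylic acid.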